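Two methylphenyl isomers in the maximal electroshock model

The source may report more compounds than this note shows. Statements on the series, on what has been measured and on what is new or still open speak of the compounds shown alone.

Compound 1 `Cc1ccc(Nc2nnc(Nc3nc(-c4ccc(Cl)cc4)cs3)s2)cc1`: 300 mg/kg
Compound 2 `Cc1ccc(Nc2nnc(Nc3nc(-c4ccc([N+](=O)[O-])cc4)cs3)s2)cc1`: 30 mg/kg
Compound 3 `Cc1ccccc1Nc1nnc(Nc2nc(-c3ccccc3)cs2)s1`: 300 mg/kg

In a functional assay on the whole organism (strain albino) with Mus musculus as the target, in the maximal electroshock model, with a stated time of 0.5 h (on this read-out lower numbers stand for an effect already at smaller amounts and higher numbers for an effect only at larger amounts of compound), compound 3 stands at 300 mg/kg, level with compound 1 at the digits given and, together with it, the highest of the three numbers. Compound 2, at 30 mg/kg, lies furthest from it. Compound 4 `Cc1ccc(Nc2nnc(Nc3nc(-c4ccccc4)cs3)s2)cc1` differs from compound 3 by 4-methylphenyl in place of 2-methylphenyl on a nitrogen on an aromatic ring. Among the measured compounds shown here, the only measured step, a 10-fold lower number from compound 1 to compound 2 (1.00 log units; beyond the scatter), concerns the substituent on the other aromatic ring and does not bear on this change; no measured pair tests the methylphenyl group itself. Compound 4 is therefore expected to show no step beyond the scatter in this assay, no change at the digits printed from compound 3 to compound 4 (within the scatter). Compound 4 is estimated at 300 mg/kg, with a range from 100 mg/kg to 600 mg/kg.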

Compound 4, minimum effective dose: 100 mg/kg
Estimate against measurement, compound 4: 3.0-fold (0.48 log units) above, and the stated range covers the measured number.
By their numbers in this assay, from the lowest: compound 2; then compound 4; then compounds 1 and 3 (each within the scatter of the next).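

In this assay, the position on the nitrogen proves not to be neutral, since 4-methylphenyl in place of 2-methylphenyl gives a 3.0-fold lower number from compound 3 to compound 4 (0.48 log units; beyond the scatter), although the same atoms are only joined differently. Compound 4 also fixes the hydrogen reference on the other aromatic ring, with a 3.0-fold lower number from compound 1 to compound 4 (0.48 log units; beyond the scatter) for hydrogen in place of chloro and a 3.3-fold higher number from compound 2 to compound 4 (0.52 log units; beyond the scatter) for hydrogen in place of nitro. No supporting data explain these steps.

From the compounds shown here alone, whether 2-methylphenyl gives the same step alongside chloro or nitro stays open. So does the outcome with methoxy or ethyl in place of the methyl group.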